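This account rests on a few compounds, and the source may have more. Where it says the series, first, only, none or still open, it means among the compounds named here.

Measured so far in a functional assay on MEL-AC cells (Homo sapiens) for cytotoxicity, read by MTT assay, with a stated time of 72 h; on this read-out lower numbers stand for stronger inhibition of growth and higher numbers for weaker inhibition of growth:
compound 1 `NC(=O)c1ccc2c(c1)S(=O)(=O)C=C2`: 3520 nM
compound 2 `CCCCNC(=O)c1ccc2c(c1)S(=O)(=O)C=C2`: 1420 nM

Compound 1 stands at the highest of the two numbers; its nearest neighbour is compound 2, and the step is a 2.5-fold lower number from compound 1 to compound 2 (0.39 log units; beyond the scatter), butyl in place of hydrogen on an amide-type nitrogen.

Compound 3 `O=S1(=O)C=Cc2ccc(O)cc21` differs from compound 1 by hydroxy in place of carbamoyl on an aromatic carbon. Among the compounds with values here, no measured step bears on this change: the step from compound 1 to compound 2 alters the amide-type nitrogen but keeps the carbamoyl. With no guide, the expected step is a 1.4-fold higher number from compound 1 to compound 3 (0.15 log units; within the scatter), not beyond the scatter, leaning toward a higher number. Compound 3 is therefore estimated at 5000 nM, range 1500 nM to 20000 nM.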

Compound 3, concentration for 50% growth inhibition: 24000 nM
For compound 3 the middle estimate is 4.8-fold (0.68 log units) below the measured one, and the stated range ends below it.
By their numbers in this assay, from the lowest: compound 2; then compound 1; then compound 3.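

In this assay, hydroxy in place of carbamoyl on an aromatic carbon gives a 6.8-fold higher number from compound 1 to compound 3 (0.83 log units; beyond the scatter), so the group at this position matters for inhibition of growth. The earlier step altered only the amide-type nitrogen and kept the carbamoyl, whereas this one removes the whole group and moves the number toward weaker inhibition. Nothing at hand accounts for the shift. As far as these compounds go, whether an amine or a carboxylic acid on this aromatic carbon would keep the level of compound 1 stays open. Also open, from the compounds shown here alone, is whether a longer chain than butyl on the amide-type nitrogen would lower the number further.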